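From ethoxy to ethyl on an aromatic carbon

The compounds below may be only part of what the source reports. "The series", "measured", "known", "first", "only" and "open" are said of these compounds alone.

In a physicochemical assay for lipophilicity, read by HPLC, at pH 7 (on this read-out higher numbers stand for higher lipophilicity and lower numbers for lower lipophilicity), compound 1 (`COc1cnc(N2CCC([C@H]3C[C@H]3COCc3ccc(S(C)(=O)=O)cc3F)CC2)nc1`) gives 4 and compound 2 (`CCOc1cnc(N2CCC([C@H]3C[C@H]3COCc3ccc(S(C)(=O)=O)c(F)c3)CC2)nc1`) gives 4.2 so the two values lie within the scatter of each other. Compound 3 (`CCc1cnc(N2CCC([C@H]3C[C@H]3COCc3ccc(S(C)(=O)=O)c(F)c3)CC2)nc1`) departs from compound 2 in one place, with ethyl in place of ethoxy on an aromatic carbon para to a large group. Among the compounds with values here, no step between measured compounds shows what this change does in this assay so only a small upward move is expected. The estimated change is a number 0.20 log units higher from compound 2 to compound 3 (within the scatter) and may not clear the usual scatter. Compound 3 is estimated at 4.4 with 4.1 to 4.7 as its expected range.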

Compound 3, distribution coefficient: 4.3
The estimate for compound 3 lay 0.10 log units above the measured number, and the stated range covers the measured number.
By their numbers in this assay, from the lowest: compounds 1, 2 and 3 (each within the scatter of the next).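

Within the data shown here, putting ethyl in place of ethoxy on an aromatic carbon gives, in this assay, the only step read at this position, a number 0.10 log units higher from compound 2 to compound 3 (within the scatter), so removing the oxygen leaves the read-out within the scatter on this core. The data offer no explanation for this result. From the compounds shown here alone, whether an amine or a longer chain such as propyl at this position would give a step beyond the scatter remains open. So does whether ethyl and ethoxy would also read alike with the fluorine placed as in compound 1.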